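Series notes: N-substituent swap on the pyrazoline nitrogen

This account rests on a few compounds, and the source may have more. Where it says the series, first, only, none or still open, it means among the compounds named here.

Compound 3 `CC(=O)N1N=C(c2ccc(Cl)cc2)CC1c1cn(-c2ccccc2)nc1-c1ccc(Cl)c(Cl)c1` gives 66.4% in a functional assay on the whole organism (strain Wistar) for inhibition, with Rattus norvegicus as the target, read by paw edema, with stated times of 30 min and 120 min, at a dose of 50 mg/kg by the oral route (a lower number here means less inhibition, a higher number more inhibition at the dose given (going by the name of the read-out)), the second highest of the three numbers; compound 1 `Fc1ccc(C2=NN(c3ccccc3)C(c3cn(-c4ccccc4)nc3-c3ccc(Cl)c(Cl)c3)C2)cc1` gives 60.2% and compound 2 `CC(=O)N1N=C(c2ccc(F)cc2)CC1c1cn(-c2ccccc2)nc1-c1ccc(Cl)c(Cl)c1` gives 72.7%, both within the scatter of compound 3. Compound 4 `Clc1ccc(C2=NN(c3ccccc3)C(c3cn(-c4ccccc4)nc3-c3ccc(Cl)c(Cl)c3)C2)cc1` differs from compound 3 by phenyl in place of acetyl on an amine nitrogen in a ring. For the measured compounds named here, the one measured step that bears on this is the opposite change, a number 12.5 percentage points higher from compound 1 to compound 2 (beyond the scatter), which is beyond the scatter. The other step, a number 6.3 percentage points lower from compound 2 to compound 3 (within the scatter), is within the scatter. Going back from acetyl to phenyl is therefore expected to lower the number by a modest amount, roughly a number 11.4 percentage points lower from compound 3 to compound 4 (beyond the scatter). Compound 4 is estimated at 55%, in the range 43% to 67%.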

Compound 4, a percentage reported as inhibition, in the whole organism at one dose (the size of the read-out at that dose, not a potency): 61.7%
Compound 4: the middle estimate sits 6.7 percentage points below what was measured, within the range that was stated.
By their numbers in this assay, from the lowest: compounds 1, 4, 3 and 2 (each within the scatter of the next, the first and the last beyond it).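

In this assay, for the compounds shown here, phenyl in place of acetyl on an amine nitrogen in a ring gives a number 4.7 percentage points lower from compound 3 to compound 4 (within the scatter), so this swap passes the scatter on only one of the two cores, and the size of the step seen first does not carry over as a firm difference, though the two readings agree: the same change on two cores in this assay, a number 12.5 percentage points higher (beyond the scatter) from compound 1 to compound 2 and a number 4.7 percentage points higher (within the scatter) from compound 4 to compound 3, 7.8 percentage points apart, within the scatter of two such steps. Chloro in place of fluoro on an aromatic carbon gives a number 1.5 percentage points higher from compound 1 to compound 4 (within the scatter), and this change now stays within the scatter on both cores: the same change on two cores in this assay, a number 6.3 percentage points lower (within the scatter) from compound 2 to compound 3 and a number 1.5 percentage points higher (within the scatter) from compound 1 to compound 4, 7.8 percentage points apart, within the scatter of two such steps.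

Open, going by these compounds, is whether a propionyl or a benzyl group on this nitrogen would separate from acetyl or phenyl. Also open, on these data alone, is how a methoxy group would read in place of the chloro or fluoro.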